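A few compounds are considered here, and "the series" means these few. Any claim that something is new, unique, unknown or untested is made for them only; others in the source may bear on it.

Compound 1: `Cn1nc2c(=O)n(CC3(O)CCN(Cc4ccc(-c5ccco5)cc4Cl)CC3)cnc2c1-c1ccc(C(F)(F)F)cc1` — 530 nM
Compound 2: `Cn1nc2c(=O)n(CC3(O)CCN(Cc4ccc(C5=CCCC5)cc4Cl)CC3)cnc2c1-c1ccc(CN)cc1` — 76.9 nM
Compound 3: `Cn1nc2c(=O)n(CC3(O)CCN(Cc4ccc(-c5ccc[nH]5)cc4Cl)CC3)cnc2c1-c1ccc(CN)cc1` — 193 nM

In an assay on isolated protein for inhibition of ubiquitin carboxyl-terminal hydrolase 7 (Homo sapiens), with stated times of 30 min and 2 h (on this read-out lower numbers stand for stronger inhibition and higher numbers for weaker inhibition), compound 1 gives 530 nM, which is the highest of the three numbers in hand. Its nearest neighbour is compound 3 at 193 nM, and the furthest is compound 2 at 76.9 nM; both gaps are beyond the scatter, so compound 1 is the weakest of the three in this assay. Among the measured compounds shown here, the single step among the measured compounds, a 2.5-fold higher number from compound 2 to compound 3 (0.40 log units; beyond the scatter), concerns a different part of the molecule from the one changed here.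

Compound 4, `Cn1nc2c(=O)n(CC3(O)CCN(Cc4ccc(-c5ccco5)cc4Cl)CC3)cnc2c1-c1ccc(Cl)cc1`, differs from compound 1 in one place: chloro in place of trifluoromethyl on an aromatic carbon. Read one bond further out, the change is from 4-(trifluoromethyl)phenyl to 4-chlorophenyl. For the measured compounds named here, no measured step touches this position, so the available numbers give no direction for the move, and a step of no size beyond the scatter is the plain expectation. On that basis compound 4 is estimated to give 500 nM, with a range from 200 nM to 1300 nM. The step that this estimate means for compound 4 is expected to be a 1.1-fold lower number from compound 1 to compound 4 (0.03 log units; within the scatter), which is within the usual scatter.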

Compound 4, half-maximal inhibitory concentration: 143 nM
Compound 4: middle estimate off by 3.5-fold (0.54 log units), on the high side; measured number outside the range, below it.
By their numbers in this assay, from the lowest: compounds 2, 4 and 3 (each within the scatter of the next, the first and the last beyond it); then compound 1.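

In this assay, the exchange of trifluoromethyl for chloro gives a 3.7-fold lower number from compound 1 to compound 4 (0.57 log units; beyond the scatter), the first step measured at this position. The earlier compounds shown here offered no step here, so they could not show whether the group on this aromatic carbon, para to a large group, affects the read-out at all; this pair shows that it does, with the rest of the molecule unchanged. The change removes four heavy atoms and introduces one, and neither group counts any hydrogen-bond donor or acceptor, so the step arises from a swap that leaves those counts the same. No measurement is available that would account for this step.

A single pair gives a direction for this one exchange only, and it cannot say whether the lower number follows from losing trifluoromethyl or from gaining chloro. The compounds shown leave open how fluoro, bromo, methyl, methoxy or a nitrile would read at the same position, and whether the same exchange would give a step of similar size in a compound with a different group elsewhere in the molecule.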